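From acetyl to methyl on the shared core

This account rests on a few compounds, and the source may have more. Where it says the series, first, only, none or still open, it means among the compounds named here.

compound 1 `CC(=O)c1ccc(OCCc2c[nH]cn2)cc1`: 3.2 mg/kg
compound 2 `O=C(c1ccc(OCCc2c[nH]cn2)cc1)N1CCCCC1`: > 10 mg/kg (a limit)
compound 3 `Fc1c(F)c(F)c(OCCc2c[nH]cn2)c(F)c1F`: 10 mg/kg

In a functional assay on the whole organism (brain) with Mus musculus as the target (a lower number here means that less compound is needed, a higher number that more compound is needed for the effect), compound 1 gives the lowest of the two actual numbers, 3.2 mg/kg. Its nearest neighbour is compound 3 at 10 mg/kg, a gap beyond the scatter. Compound 2 reaches only a limit of the assay, > 10 mg/kg.

Compound 4 `Cc1ccc(OCCc2c[nH]cn2)cc1` changes the acetyl of compound 1: methyl in place of acetyl on an aromatic carbon. Among the measured compounds shown here, the one measured step at this acetyl group is an at least 3.1-fold higher number from compound 1 to compound 2 (0.49 log units; beyond the scatter), and its size is bounded by a limit. That step keeps the carbonyl, whereas compound 4 loses it, so it is only a loose guide. Compound 3 also has no acetyl and gives 10 mg/kg. A modest rise in this assay is therefore expected, with the estimated step being a 2.2-fold higher number from compound 1 to compound 4 (0.34 log units; beyond the scatter). For compound 4 the estimated value is 7 mg/kg, with an expected range from 2 mg/kg to 20 mg/kg.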

Compound 4, dose for half-maximal effect: 2.3 mg/kg
For compound 4 the middle estimate is 3.0-fold (0.48 log units) above the measured one, within the range that was stated.
By their numbers in this assay, from the lowest: compounds 4 and 1 (each within the scatter of the next); then compound 3.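

In this assay, methyl in place of acetyl on an aromatic carbon leaves the number within the scatter (a 1.4-fold lower number from compound 1 to compound 4 (0.14 log units; within the scatter)), so the effect at this position does not depend on the acetyl or its carbonyl. The earlier step (an at least 3.1-fold higher number from compound 1 to compound 2 (0.49 log units; beyond the scatter)) kept the carbonyl and still raised the number, which shows that the carbonyl alone does not settle the value here and that the rest of the group matters. Nothing measured for these compounds explains why the acetyl and the methyl compounds fall so close together.

On these data alone, it remains open whether a longer chain such as ethyl or propyl, a methoxy group or a chlorine would hold the number at this position. As far as these compounds go, it is equally open how an amine or a carboxylic acid would fare there.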